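Amide aryl change on the benzoyl-bearing core

This account rests on a few compounds, and the source may have more. Where it says the series, first, only, none or still open, it means among the compounds named here.

Working notes on the series. Two compounds carry numbers in a functional assay on PC-3 cells (Homo sapiens) for cytotoxicity, read by sulforhodamine B assay, with a stated time of 72 h; a higher number here means a weaker inhibitor of growth, a lower number a stronger inhibitor of growth. Compound 1 `CC(=O)N1c2ccccc2CCC1C(=O)Nc1ccccc1O` gives 70700 nM in this assay. Compound 2 `O=C(Nc1ccccc1C(F)(F)F)C1CCc2ccccc2N1C(=O)c1ccccc1` gives 5560 nM in this assay, the lower of the two numbers, and the value of compound 1 stands beyond the scatter above it. Compounds 1 and 2 differ in two places, on the ring nitrogen and on the amide aryl, so neither change can be read on its own from what has been measured.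

Compound 3 `O=C(Nc1ccccc1O)C1CCc2ccccc2N1C(=O)c1ccccc1` is not yet measured in this assay. Within the data shown here, it keeps the benzoyl of compound 2 and differs from it by hydroxy in place of trifluoromethyl on an aromatic carbon; the hydroxyphenyl amide is the one found in compound 1.

Among the measured compounds shown here, no measured pair shows this change alone. The step of a 4.0-fold higher number from compound 2 to compound 3 (0.60 log units; beyond the scatter) is expected to run toward a higher number, beyond the scatter, because compound 1 with the same amide aryl gives 70700 nM. Compound 3 is estimated at 22000 nM in this assay, with a range of 6500 nM to 75000 nM.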

Compound 3, concentration for 50% growth inhibition: 5690 nM
Beside the measured number, compound 3's estimate is 3.9-fold (0.59 log units) above it; measured number below the stated range.
By their numbers in this assay, from the lowest: compounds 2 and 3 (each within the scatter of the next); then compound 1.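

In this assay the amide aryl change from 2-(trifluoromethyl)phenyl to 2-hydroxyphenyl on the benzoyl-bearing core gives (a 1.0-fold higher number from compound 2 to compound 3 (0.01 log units; within the scatter)), so with benzoyl on the ring nitrogen, hydroxy and trifluoromethyl at this place on the aromatic ring, ortho to a large group, cannot be told apart in growth inhibition. The new compound also isolates the change on the ring nitrogen, which the earlier pair could not do: with the 2-hydroxyphenyl amide held constant, phenyl in place of methyl on a carbonyl carbon gives (a 12-fold lower number from compound 1 to compound 3 (1.09 log units; beyond the scatter)), and among the steps that can be read, this is the one that lies beyond the scatter. No supporting measurement accompanies these numbers that could account for either the flat step on the amide aryl or the large step on the ring nitrogen.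

Open, from the compounds shown here alone, is whether the amide aryl stays as silent with acetyl on the ring nitrogen as it does with benzoyl, since the 2-(trifluoromethyl)phenyl amide appears here only with benzoyl. Also open, going by these compounds, is how an amine or a carboxylic acid would read at this same aromatic carbon, and how a longer chain would read on the ring nitrogen carbonyl in place of phenyl or methyl.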